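This account rests on a few compounds, and the source may have more. Where it says the series, first, only, none or still open, it means among the compounds named here.

Measured so far:
- compound 1 `COc1cccc([C@H](O)[C@H]2CO[C@H](c3ccc(OC)c(OC)c3)[C@@H](C/C=C/c3ccc(OC)c(OC)c3)C2)c1`: 21200 nM
- compound 2 `COc1cccc([C@H](O)[C@H]2CO[C@@H](c3ccc(OC)c(OC)c3)[C@H](C/C=C/c3ccc(OC)c(OC)c3)C2)c1`: 18600 nM

In a functional assay on HeLa cells (Homo sapiens) for cytotoxicity, read by WST assay, with a stated time of 48 h (a higher number here means a weaker inhibitor, a lower number a stronger inhibitor), compound 2 gives 18600 nM, level with compound 1 within the scatter. Compound 3 `COc1ccc(/C=C/C[C@@H]2C[C@@H]([C@@H](O)c3ccccc3)CO[C@H]2c2ccc(OC)c(OC)c2)cc1OC` follows from compound 2 by one change, hydrogen in place of methoxy on an aromatic carbon, so 3-methoxyphenyl becomes phenyl.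

Among the measured compounds shown here, the only measured step is a 1.1-fold lower number from compound 1 to compound 2 (0.06 log units; within the scatter). It concerns (the fact that compounds 1 and 2 differ only in the configuration as drawn), so it bears only indirectly on this change and gives no measured size for removing the methoxy group. For the measured compounds named here, it shows only that these numbers stayed level across a change in configuration. No shift beyond the scatter is therefore expected in this assay, and no direction is favoured, though the range is kept wide. The expected step is a 1.1-fold higher number from compound 2 to compound 3 (0.03 log units; within the scatter). For compound 3 the estimated value is 20000 nM, with an expected range of 9000 nM to 45000 nM.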

Compound 3, half-maximal inhibitory concentration: 16800 nM
Beside the measured number, compound 3's estimate is 1.2-fold (0.08 log units) above it, and the stated range covers the measured number.
By their numbers in this assay, from the lowest: compounds 3, 2 and 1 (each within the scatter of the next).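

Hydrogen in place of methoxy on the aromatic carbon gives a 1.1-fold lower number from compound 2 to compound 3 (0.04 log units; within the scatter) in this assay and thus adds a measured step at this position, where the earlier pair compared only configuration. With 3-methoxyphenyl changed to phenyl, the number stays level within the scatter, so in this series the methoxy group at this position is not needed to keep the micromolar-range reading of compound 2. Nothing available gives a reason for this step.

On these data alone, whether an amine or a carboxylic acid on the same aromatic carbon would stay level with compound 3 remains open. Also open, as far as these compounds go, are the effects of moving the methoxy group to another carbon of this ring and of removing the remaining methoxy groups on the shared core.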